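Open chain in place of ring in compound 4

This account rests on a few compounds, and the source may have more. Where it says the series, first, only, none or still open, it means among the compounds named here.

In an ADME assay on microsomes from liver (Mus musculus) for metabolic stability (on this read-out lower numbers stand for a less stable compound and higher numbers for a more stable compound), compound 3 `N[C@H]1CC[C@H](N(C[C@H]2Cc3ccccc3CN2)[C@H]2CCCc3cccnc32)CC1` gives 77%, the highest of the three numbers. Compound 1 `C/C(CN(C[C@H]1Cc2ccccc2CN1)[C@H]1CCCc2cccnc21)=C(/F)CN` gives 15% and compound 2 `C/C(CN(C[C@H]1Cc2ccccc2CN1)[C@H]1CCCc2cccnc21)=C(\F)CN` gives 1%.

The next comparison is compound 3 with compound 4 `C/C(=C/CN)CN(C[C@H]1Cc2ccccc2CN1)[C@H]1CCCc2cccnc21`: a group of 6 heavy atoms (5 carbon, 1 nitrogen; no ring) in place of a group of 7 heavy atoms (6 carbon, 1 nitrogen; one six-membered non-aromatic ring of carbon only), on an amine nitrogen. On an amine nitrogen, the 4-aminocyclohexyl group gives way to a group with no ring and one double bond outside aromatic rings.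

The closest evidence comes from the two compounds that carry an open chain at the same place, 4-amino-3-fluoro-2-methylbut-2-en-1-yl. Both steps to the ring are large: a number 62 percentage points higher from compound 1 to compound 3 (beyond the scatter) and a number 76 percentage points higher from compound 2 to compound 3 (beyond the scatter). The change to compound 4 runs the opposite way, from ring to open chain, so a large fall is expected. The open-chain pair also differs within itself, a number 14 percentage points lower from compound 1 to compound 2 (beyond the scatter), a modest step that rests on (the fact that compounds 1 and 2 differ only in the configuration as drawn). The geometry of the chain therefore matters to some degree, and the range has to stay wide. The chain of compound 4 is not identical to either of those chains, which adds further uncertainty.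

The expected change is a number 65 percentage points lower from compound 3 to compound 4 (beyond the scatter). Compound 4 is estimated at 12%, with an expected range of 2% to 35%.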

Compound 4, percent of the compound remaining: 2%
Estimate against measurement, compound 4: 10 percentage points above; low and high end bracket the measured number.
By their numbers in this assay, from the lowest: compounds 2 and 4 (each within the scatter of the next); then compound 1; then compound 3.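

Loss of the fluorine from the open chain does not lift the number in this assay: the step of a number 1 percentage points higher from compound 2 to compound 4 (within the scatter) shows no separation from the fluorinated chain of compound 2, while a number 13 percentage points lower from compound 1 to compound 4 (beyond the scatter) places the new chain modestly under the fluorinated chain of compound 1. Fluorine is therefore not required for the low numbers, and the drop on leaving 4-aminocyclohexyl at this amine nitrogen, a number 75 percentage points lower from compound 3 to compound 4 (beyond the scatter), holds for a chain without fluorine as well, so that all three open-chain compounds lie far under compound 3, with none of the four going against this. Among the open chains, the step of a number 14 percentage points lower from compound 1 to compound 2 (beyond the scatter) remains the only separation between the two fluorinated compounds, and its basis is: the fact that compounds 1 and 2 differ only in the configuration as drawn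

The step from compound 3 to compound 4 changes the ring and the double bond together, so the compounds shown cannot say which of the two goes with the fall. A saturated 4-aminobutyl chain, or a smaller ring such as 3-aminocyclobutyl, on the same amine nitrogen would bear on that question.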